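The compounds below may be only part of what the source reports. "The series", "measured", "known", "first", "only" and "open" are said of these compounds alone.

Measured so far: compound 1 `CCCOC(=O)/C=C(C)/C=C/CC(C)CCCC(C)C` gives 7.28 in a physicochemical assay for lipophilicity; on this read-out lower numbers stand for lower lipophilicity and higher numbers for higher lipophilicity; compound 2 `CC(/C=C/CC(C)CCCC(C)C)=C\C(=O)OCC(C)C` gives 7.69; compound 3 `CCCOC(=O)/C=C(C)/C=C/CC(C)CCCC(C)(C)OC` gives 6.08.

Compound 3 stands lowest of the three numbers, set apart from compound 1 by a number 1.20 log units lower from compound 1 to compound 3 (beyond the scatter) and furthest from compound 2. Compound 4 `C=CC(C)OC(=O)/C=C(C)/C=C/CC(C)CCCC(C)(C)OC` differs from compound 3 by 1-methylprop-2-en-1-yl in place of propyl on an oxygen next to a carbonyl group. Among the measured compounds shown here, no measured step covers this change. The nearest comparison is a number 0.41 log units higher from compound 1 to compound 2 (beyond the scatter), which also adds one carbon, though here a double bond enters as well. A small upward step is therefore expected for compound 4, at or near the scatter, a number 0.22 log units higher from compound 3 to compound 4 (within the scatter). Compound 4 is estimated at 6.3, in the range 5.8 to 6.8.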

Compound 4, partition coefficient: 5.94
Compound 4: middle estimate off by 0.36 log units, on the high side; the range from low to high includes it.
By their numbers in this assay, from the lowest: compounds 4 and 3 (each within the scatter of the next); then compound 1; then compound 2.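

In this assay, placing 1-methylprop-2-en-1-yl in place of propyl on an oxygen next to a carbonyl group gives a number 0.14 log units lower from compound 3 to compound 4 (within the scatter), so this larger group with its double bond leaves the number within the scatter. The earlier step, a number 0.41 log units higher from compound 1 to compound 2 (beyond the scatter), lay beyond the scatter, so enlarging this group need not carry the number that far. Nothing available accounts for this result.

From the compounds shown here alone, whether a longer chain, an amine or a carboxylic acid on this oxygen would shift the number stays open. So does whether this change behaves alike on compound 1, which lacks the methoxy.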